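The source may report more compounds than this note shows. Statements on the series, on what has been measured and on what is new or still open speak of the compounds shown alone.

Measured so far in a functional assay on OVCAR-3 cells (Homo sapiens) for antiproliferative activity, read by MTT assay, with a stated time of 24 h; a higher number here means a weaker inhibitor, a lower number a stronger inhibitor:
- compound 1 `O=C(NNc1ccccc1F)c1ccc(NS(=O)(=O)c2cnc(O)nc2O)cc1`: > 20000 nM (a limit)
- compound 2 `Cc1cccc(NNC(=O)c2cccc(NS(=O)(=O)c3cnc(O)nc3O)c2)c1`: > 20000 nM (a limit)
- compound 3 `O=C(NNC(=O)c1ccccc1F)c1ccc(NS(=O)(=O)c2cnc(O)nc2O)cc1`: 16000 nM

Compound 2 sits at the limit of > 20000 nM in this assay, at which 2 of the 3 values shown sit. That is a limit and not a number, so the starting point of this step is open.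

Compound 4 `Cc1ccc(C(=O)NNC(=O)c2cccc(NS(=O)(=O)c3cnc(O)nc3O)c2)cc1` changes compound 2 at one place: (4-methylphenyl)carbonyl in place of 3-methylphenyl on an amine nitrogen. In words, (4-methylphenyl)carbonyl stands in place of 3-methylphenyl on an amine nitrogen.

Among the measured compounds shown here, only one measured step bears on this: an at least 1.2-fold lower number from compound 1 to compound 3 (0.09 log units; that floor lies within the scatter). It is the same kind of swap, with a carbonyl entering on an amine nitrogen. Going by these compounds, its true size is unknown, and the part that can be seen stays within the scatter. In this assay a small move toward a lower number is therefore expected, and nothing clearly beyond the scatter.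

The expected step is an at least 1.1-fold lower number from compound 2 to compound 4 (0.04 log units; that floor lies within the scatter).

For compound 4 the estimated value is 18000 nM, with an expected range from 9000 nM to 40000 nM.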

Compound 4, half-maximal inhibitory concentration: > 20000 nM
Compound 4 ended at the assay's limit; the forecaster's own chance of this, stated with the estimate: 55%; middle value at least 1.1-fold (0.04 log units) away from the limit.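

In this assay, among the compounds shown here, no step from compound 2 to compound 4 can be read, because both compounds stop at a limit and not a number: the limit of > 20000 nM in this assay, at which 3 of the 4 values shown sit.

The compounds shown leave open how far compound 2 and compound 4 lie past that limit, and whether the swap to (4-methylphenyl)carbonyl changes the activity at all.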